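The source may report more compounds than this note shows. Statements on the series, on what has been measured and on what is new or still open speak of the compounds shown alone.

Three compounds have been measured in a functional assay on the whole organism for inhibition, with Rattus norvegicus as the target, read by paw edema; on this read-out lower numbers stand for an effect already at smaller amounts and higher numbers for an effect only at larger amounts of compound:

compound 1 `O=C(O)c1cc(-c2cocn2)ccc1O`, 110 mg/kg
compound 2 `CC(=O)Oc1ccc(-n2cccc2)cc1C(=O)O`, 42 mg/kg
compound 3 `O=C(O)c1cc(C2N=NN=N2)ccc1O`, 110 mg/kg

On these numbers compound 1 stands level with compound 3, and the two together are the highest of the three. Within the data shown here, compound 2 lies a clear distance below them, beyond the scatter, but compound 2 differs from compound 1 in more than one place and no single step links the two, so its value only marks where the lower end of the set lies. Compound 4 `O=C(O)c1cc(-c2cccs2)ccc1O` has not been measured. It differs from compound 1 by thiophen-2-yl in place of 1,3-oxazol-4-yl on an aromatic carbon. Among the measured compounds shown here, the one measured step that bears on this change is no change at the digits printed from compound 1 to compound 3 (within the scatter), where one five-membered ring replaced another on the same aromatic carbon and the number in this assay did not move beyond the scatter. A further exchange of that ring is therefore expected to bring little: for compound 4 the step of a 1.1-fold lower number from compound 1 to compound 4 (0.04 log units; within the scatter) is expected to stay within the scatter. Compound 4 is estimated at 100 mg/kg, within a range from 45 mg/kg to 220 mg/kg.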

Compound 4, dose for half-maximal effect: 60 mg/kg
For compound 4 the middle estimate is 1.7-fold (0.22 log units) above the measured one; low and high end bracket the measured number.
By their numbers in this assay, from the lowest: compounds 2, 4, 1 and 3 (each within the scatter of the next, the first and the last beyond it).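

Thiophen-2-yl, with its carbon and sulfur ring atoms, replaced 1,3-oxazol-4-yl on the aromatic carbon para to the hydroxy group and meta to the carboxy group, and this assay gave a 1.8-fold lower number from compound 1 to compound 4 (0.26 log units; within the scatter). The earlier compounds had shown only rings holding nitrogen at this carbon, so this is the first sign that a ring without nitrogen or oxygen also stays within the scatter, and the comparison with the tetrazole-type ring gives a 1.8-fold lower number from compound 3 to compound 4 (0.26 log units; within the scatter). Nothing measured here explains these small differences. The compounds shown leave open whether a six-membered ring such as phenyl at this carbon would move the number beyond the scatter. They also leave open what an open group, such as an amine or a longer alkyl chain, would do there.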